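The source may report more compounds than this note shows. Statements on the series, on what has been measured and on what is new or still open speak of the compounds shown alone.

Compound 1, `O=S(=O)(Nc1ccc(-c2nc3ccccc3o2)cc1)c1cccs1`, is one of three compounds tested in an assay on isolated protein for inhibition of malate dehydrogenase, mitochondrial (Sus scrofa), with stated times of 45 min and 30 min; on this read-out lower numbers stand for stronger inhibition and higher numbers for weaker inhibition. In this assay compound 1 gives only a limit and no number, > 63000 nM. Compound 2, `O=S(=O)(Nc1ccc2oc(-c3ccccc3)nc2c1)c1ccccc1C(F)(F)F`, likewise gives only a limit in this assay, > 63000 nM. Compound 3, `O=S(=O)(Nc1ccc2oc(-c3ccccc3)nc2c1)c1ccc(Cl)c(C(F)(F)F)c1`, too gives only a limit in this assay, > 63000 nM. Compound 1 therefore stands at the limit of > 63000 nM in this assay, at which 3 of the 3 values shown sit, with nothing to set it apart from the others.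

Compound 4, `COc1ccccc1S(=O)(=O)Nc1ccc(-c2nc3ccccc3o2)cc1`, has not yet been measured. It differs from compound 1 in one place: 2-methoxyphenyl in place of thiophen-2-yl on a sulfonyl sulfur. Going by the values given here, no two measured compounds differ in only one place, so no measured step exists to lean on.

With every measured compound resting at the limit, the change is expected to be none beyond the scatter. The step of a number no higher from compound 1 to compound 4 (the limit leaves the size open) is expected to be small or absent. Compound 4 is thus estimated at 63000 nM, with a range from 20000 nM to 200000 nM, and most likely reported only as a limit.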

Compound 4, half-maximal inhibitory concentration: > 63000 nM
Compound 4: no number, only a limit (the forecaster's own chance of this, stated with the estimate: 80%); the middle value lies on the limit itself.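

Compound 1 and compound 4 each give only a limit in this assay, so no step between them can be read: the limit of > 63000 nM in this assay, at which 4 of the 4 values shown sit.

The compounds shown leave open whether any change to their structures would give a readable number in this assay.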